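The compounds below may be only part of what the source reports. "The series", "measured", "known", "first", "only" and "open" are said of these compounds alone.

Measured compounds:
compound 1 `c1cncc(N2CCCNCCC2)c1` — 0.891 nM
compound 2 `COc1cc(N2CCCNCC2)cnc1Cl` — 0.676 nM
compound 3 `C/C=C\Oc1cncc(N2CCCNCC2)c1` — 1.29 nM

In an assay on HEK293 cells for displacement of a labelled ligand from Neuronal acetylcholine receptor; alpha4/beta2 (Homo sapiens) (a higher number here means a weaker inhibitor, a lower number a stronger inhibitor), compound 1 gives 0.891 nM. Compound 2 and compound 3 give numbers close to it on either side, and neither gap is beyond the usual scatter, so the three measured compounds cannot be told apart on this assay.

Compound 4 `Brc1cncc(N2CCCNCCC2)c1` is not yet measured. It differs from compound 1 by bromo in place of hydrogen on an aromatic carbon, the bromo entering two atoms from the ring nitrogen, meta to a group of 8 heavy atoms. For the measured compounds named here, no measured pair shows this change, so the step is an expectation only. Compound 4 is expected to move the number downward by a 2.0-fold lower number from compound 1 to compound 4 (0.30 log units; within the scatter), a small step that may not clear the scatter. The estimate for compound 4 in this assay is 0.45 nM, with a range from 0.12 nM to 1.6 nM.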

Compound 4, half-maximal inhibitory concentration: 2.82 nM
Beside the measured number, compound 4's estimate is 6.3-fold (0.80 log units) below it, outside the stated range (above it).
By their numbers in this assay, from the lowest: compounds 2, 1 and 3 (each within the scatter of the next); then compound 4.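

In this assay, bromo in place of hydrogen on an aromatic carbon, two atoms from the ring nitrogen, gives a 3.2-fold higher number from compound 1 to compound 4 (0.50 log units; beyond the scatter) and is the only step shown that clears the scatter. For the compounds shown here, the earlier compounds could not be told apart, so this is the first sign that the number responds to a change at this position, and it moves upward rather than downward. Nothing on hand accounts for the step.

On these data alone, whether a nitrile or an amine at this place would move the number the same way remains open. Also open, as far as these compounds go, is whether bromo gives a step of this size on the core of compound 3.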